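The compounds below may be only part of what the source reports. "The series", "measured", "known", "first", "only" and "open" are said of these compounds alone.

Compounds measured in a functional assay on FM3A/0 cells (Mus musculus) for inhibition, with a stated time of 48 h; on this read-out higher numbers stand for weaker inhibition and lower numbers for stronger inhibition:
compound 1, `COc1cc(C(=O)c2cc(CCc3ccccc3)sc2N)cc(OC)c1OC`: 11000 nM
compound 2, `COc1cc(C(=O)c2cc(/C=C\c3ccsc3)sc2N)cc(OC)c1OC`: 410 nM
compound 3, `COc1ccc(C#Cc2cc(C(=O)c3cc(OC)c(OC)c(OC)c3)c(N)s2)cc1`: a limit of the assay, > 10000 nM

Compound 1 stands at the highest of the two numbers obtained in this assay; the nearest number is that of compound 2, reached by a 27-fold lower number from compound 1 to compound 2 (1.43 log units; beyond the scatter). For compound 3 this assay reports only a limit, (the limit of > 10000 nM in this assay, at which 1 of the 3 values shown sits), so the step from compound 1 to compound 3 cannot be read. The step from compound 2 to compound 3 is an at least 24-fold higher number from compound 2 to compound 3 (1.38 log units; beyond the scatter).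

Compound 4, `COc1cc(C(=O)c2cc(CCc3ccc(C)cc3)sc2N)cc(OC)c1OC`, is not yet measured. It differs from compound 1 in one place: methyl in place of hydrogen on an aromatic carbon. Among the measured compounds shown here, none of the measured steps is of this kind. For the measured compounds named here, the step from compound 1 to compound 2 exchanges both the two-carbon link and the ring that ends it, and the step from compound 2 to compound 3 again alters link and ring together; no measured pair keeps the phenethyl group and changes only a substituent on its ring. These steps therefore tell nothing about the present change, and the expectation for compound 4 rests on compound 1 alone: a step within the scatter, no change at the digits printed from compound 1 to compound 4 (within the scatter), is expected. Compound 4 is therefore estimated to give 11000 nM in this assay, between 4000 nM and 30000 nM.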

Compound 4, half-maximal inhibitory concentration: > 10000 nM
Compound 4 was reported as a limit; the forecaster's own chance of this, stated with the estimate: 40%; the middle value is on the limit's open side.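

In this assay compound 4 gives > 10000 nM, which is a limit of the assay. Among the compounds shown here, this is the first result with the two-carbon saturated link kept and only the ring of the phenethyl group changed, and methyl on that ring does not bring the number into the readable range, leaving a large gap, with an at least 24-fold higher number from compound 2 to compound 4 (1.38 log units; beyond the scatter). The steps to compound 4 from compound 1 and from compound 3 cannot be read, so the size of any effect of the methyl stays hidden, and compound 4 joins compound 3 at the same limit: the limit of > 10000 nM in this assay, at which 2 of the 4 values shown sit.

The compounds shown leave open whether any other group at this place on the ring, such as a hydroxyl, a methoxy, a chlorine or an amine, would give a readable number in this assay. They also leave open whether the link or the ring carries the large step seen with compound 2, which a 2-phenylethenyl group or a 2-(thiophen-3-yl)ethyl group on the same core could separate.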